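Three Anilides at the Assay Limit, and a Fourth

A few compounds are considered here, and "the series" means these few. Any claim that something is new, unique, unknown or untested is made for them only; others in the source may bear on it.

Compound 1, `CC(=O)C(=O)NCCCCCC(=O)Nc1ccccc1`, in a functional assay on HCT-116 cells (Homo sapiens) for inhibition, read by colorimetric assay, with a stated time of 3 days; a lower number here means a stronger inhibitor, a higher number a weaker inhibitor: > 100000 nM, a limit of the assay, not a number.
Compound 2, `O=C(CCCCCNC(=O)c1ccc[nH]1)Nc1ccccc1`, in this assay: > 100000 nM, also a limit.
Compound 3, `O=C(CCCCCNC(=O)c1cc(=O)c(O)co1)Nc1ccccc1`, in this assay: > 100000 nM, again a limit.

Compound 3 therefore stands nowhere readable: all three compounds sit at the same limit, as the limit of > 100000 nM in this assay, at which 3 of the 3 values shown sit, shows. The steps a step that the two limits leave unreadable from compound 1 to compound 3 and a step that the two limits leave unreadable from compound 2 to compound 3 cannot be sized, and neither can a step that the two limits leave unreadable from compound 1 to compound 2.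

Compound 4, `CC(C)(C)C(O)(O)C(=O)NCCCCCC(=O)Nc1ccccc1`, differs from compound 3 by a group of 7 heavy atoms (5 carbon, 2 oxygen; no ring) in place of a group of 8 heavy atoms (5 carbon, 3 oxygen; one six-membered aromatic ring with 1 hetero atom), on a carbonyl carbon. Within the data shown here, no measured step bears readably on this change, so the expectation is that compound 4 stays at the limit, with a number no higher from compound 3 to compound 4 (the limit leaves the size open) expected to be no step beyond the scatter. Compound 4 is estimated at 100000 nM, within 30000 nM to 300000 nM.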

Compound 4, half-maximal inhibitory concentration: 54400 nM
Compound 4: middle estimate off by 1.8-fold (0.26 log units), on the high side; the range from low to high includes it.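

On this carbonyl carbon, 1,1-dihydroxy-2,2-dimethylpropyl yields a readable number: in this assay compound 4 gives 54400 nM. The change can now be bounded on one side, as an at least 1.8-fold lower number from compound 3 to compound 4 (0.26 log units; that floor lies within the scatter), an at least 1.8-fold lower number from compound 2 to compound 4 (0.26 log units; that floor lies within the scatter) and an at least 1.8-fold lower number from compound 1 to compound 4 (0.26 log units; that floor lies within the scatter), though none of these floors shows a real difference. Only compound 4 has left the limit: the limit of > 100000 nM in this assay, at which 3 of the 4 values shown sit.

From the compounds shown here alone, the true size of each step stays open. So does whether an amine or a carboxylic acid on this carbonyl carbon would give a lower number.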